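Bornyl ester piperazines: cytotoxicity notes toward compound 4

The source may hold more compounds than are shown below. What is called first, only, known or untested is meant among the compounds shown, and "the series" means these compounds.

Measured so far:
compound 1 `CN1CCN(CCC(=O)O[C@@H]2C[C@@H]3CC[C@@]2(C)C3(C)C)CC1`, 282000 nM
compound 2 `CN1CCN(CCCC(=O)O[C@@H]2C[C@@H]3CC[C@@]2(C)C3(C)C)CC1`, 99200 nM
compound 3 `CCN1CCN(CCC(=O)O[C@@H]2C[C@@H]3CC[C@@]2(C)C3(C)C)CC1`, 264000 nM

In an ADME assay on HEK-293T cells (Homo sapiens) for cytotoxicity, read by MTT assay, with a stated time of 48 h (a lower number here means that less compound is tolerated, a higher number that more compound is tolerated), compound 3 stands second highest of the three numbers; its nearest neighbour is compound 1, with a 1.1-fold lower number from compound 1 to compound 3 (0.03 log units; within the scatter), and its furthest is compound 2, whose value is beyond the scatter from it.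

Compound 4 `CCOC(=O)N1CCN(CCC(=O)O[C@@H]2C[C@@H]3CC[C@@]2(C)C3(C)C)CC1` differs from compound 3 by ethoxycarbonyl in place of ethyl on an amine nitrogen in a ring. Among the measured compounds shown here, the only measured step at the ring nitrogen is a 1.1-fold lower number from compound 1 to compound 3 (0.03 log units; within the scatter), a small change that left the number essentially where it was. For the measured compounds named here, no measured step covers ethoxycarbonyl in place of ethyl, so a step beyond the scatter is not expected in either direction for this assay.

Compound 4 is therefore expected near compound 3, with a 1.1-fold lower number from compound 3 to compound 4 (0.02 log units; within the scatter), estimated at 250000 nM in a range from 100000 nM to 600000 nM.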

Compound 4, half-maximal cytotoxic concentration: 110000 nM
For compound 4 the middle estimate is 2.3-fold (0.36 log units) above the measured one; the range from low to high includes it.
By their numbers in this assay, from the lowest: compounds 2 and 4 (each within the scatter of the next); then compounds 3 and 1 (each within the scatter of the next).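

In this assay ethoxycarbonyl in place of ethyl on the ring amine nitrogen gives a 2.4-fold lower number from compound 3 to compound 4 (0.38 log units; beyond the scatter) and in place of methyl gives a 2.6-fold lower number from compound 1 to compound 4 (0.41 log units; beyond the scatter) on the same nitrogen. This position therefore responds to the group it carries, which a 1.1-fold lower number from compound 1 to compound 3 (0.03 log units; within the scatter) did not show. No measurement at hand bears on the reason for this shift.

On these data alone, whether the shift follows from the carbonyl or from the ethoxy part remains open. An acetyl group or a longer alkyl chain such as butyl on this nitrogen would separate the two.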